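The source may hold more compounds than are shown below. What is called first, only, known or untested is meant among the compounds shown, and "the series" means these compounds.

So far three compounds on one shared core have been read in a functional assay on PC-3 cells (Homo sapiens) for inhibition, read by MTT assay, with a stated time of 72 h; on this read-out lower numbers stand for stronger inhibition and higher numbers for weaker inhibition. Compound 1 (`C#CCSc1nc(NCCC(C)C)c2ccncc2n1`) gives > 80000 nM there, which is a limit and not a number. Compound 2 (`C#CCSc1nc(Nc2ccccc2)c2ccncc2n1`) gives > 80000 nM as well, again only a limit, so it stands at the limit of > 80000 nM in this assay, at which 2 of the 3 values shown sit, and has no exact place. For the measured compounds named here, compound 3 (`C#CCSc1nc(Nc2ccc(C)cc2)c2ccncc2n1`) is the only one with a real number, reading 15700 nM in this assay under the same conditions.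

Compound 4 (`C#CCSc1nc(Nc2ccccc2O)c2ccncc2n1`) puts hydroxy in place of hydrogen on an aromatic carbon of compound 2, ortho to a large group, which turns phenyl into 2-hydroxyphenyl (hydroxy in place of hydrogen on an aromatic carbon). Among the measured steps, a step that the two limits leave unreadable from compound 1 to compound 2 gives no size. The closest guide is an at least 5.0-fold lower number from compound 2 to compound 3 (0.70 log units; beyond the scatter) for methyl in place of hydrogen on an aromatic carbon, and an at least 5.0-fold lower number from compound 1 to compound 3 (0.70 log units; beyond the scatter) rests on the same reading of compound 3. Both sizes are bounds only, and hydroxy is not methyl, so this guide is weak.

A modest step towards a lower number is therefore expected, estimated as an at least 1.7-fold lower number from compound 2 to compound 4 (0.24 log units; that floor lies within the scatter) in this assay with a real chance of no readable number. Compound 4 is estimated at 45000 nM with an expected range from 12000 nM to 100000 nM in this read-out.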

Compound 4, half-maximal inhibitory concentration: 18700 nM
Compound 4: the middle estimate sits 2.4-fold (0.38 log units) above what was measured; the measured number falls inside the stated range.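

In this assay, hydroxy in place of hydrogen on an aromatic carbon, ortho to a large group, gives an at least 4.2-fold lower number from compound 2 to compound 4 (0.63 log units; beyond the scatter), so the methyl of compound 3 is no longer the only change on the phenyl shown to bring a readable number. The two substituted rings cannot be told apart in this read-out, with a 1.2-fold higher number from compound 3 to compound 4 (0.08 log units; within the scatter), which puts 2-hydroxyphenyl and 4-methylphenyl on the same level within the scatter, although they carry different groups at different places on the ring. Set against the isopentyl of compound 1, 2-hydroxyphenyl gives an at least 4.2-fold lower number from compound 1 to compound 4 (0.63 log units; beyond the scatter), and this step, like the one from compound 2, is a bound and not an exact size, as it starts from a limit: the limit of > 80000 nM in this assay, at which 2 of the 4 values shown sit.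

The compounds shown leave open whether a methoxy, an amine or a chlorine in the same place would read like hydroxy, and whether hydroxy and methyl together on one ring would go further than either alone. How large the gain over the plain phenyl truly is also stays open, and so does what lies behind it.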